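Trimming the propyl from compound 1's side chain

The source may hold more compounds than are shown below. What is called first, only, known or untested is meant among the compounds shown, and "the series" means these compounds.

Of the compounds shown here, two have been measured in a functional assay on HBL-100 cells (Homo sapiens) for antiproliferative activity, read by sulforhodamine B assay, with a stated time of 48 h; on this read-out higher numbers stand for weaker inhibition of growth and lower numbers for stronger inhibition of growth. Compound 1, `CCCCC(C#CC(=O)OC)O/C=C/C(=O)OC`, gives 250 nM in this assay, the lower of the two numbers. Compound 2, `CCOC(=O)C#CCO/C=C/C(=O)OC`, gives 2400 nM in this assay, and the gap between these two values lies beyond the scatter; compound 2 differs from compound 1 in more than one place, so nothing is attributed to any single change there. Compound 3, `COC(=O)C#CC(C)O/C=C/C(=O)OC`, is not yet measured. It differs from compound 1 by one change: hydrogen in place of propyl on a saturated chain carbon, two bonds along the chain from an oxygen on an unsaturated carbon and a triple-bonded carbon. Going by the values given here, no step between measured compounds isolates this change. Among the compounds with values here, the only guidance is that compound 2, which also lacks the propyl, gives the higher value 2400 nM, though other differences cloud that reading. Compound 3 is therefore expected to be weaker than compound 1, with an expected step of a 3.2-fold higher number from compound 1 to compound 3 (0.51 log units; beyond the scatter). Compound 3 is estimated at 800 nM, within a range of 300 nM to 2500 nM.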

Compound 3, concentration for 50% growth inhibition: 300 nM
Compound 3: middle estimate off by 2.7-fold (0.43 log units), on the high side; measured number inside the range.
By their numbers in this assay, from the lowest: compounds 1 and 3 (each within the scatter of the next); then compound 2.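

In this assay, going by these compounds alone, the step of a 1.2-fold higher number from compound 1 to compound 3 (0.08 log units; within the scatter) gives the first direct reading at this position, for hydrogen in place of propyl on a saturated chain carbon, two bonds along the chain from an oxygen on an unsaturated carbon and a triple-bonded carbon. Cut one bond further out, the same difference reads butyl to methyl, and this shortening leaves the number within the scatter, so the full butyl is not needed here to hold antiproliferative activity at the level of compound 1. Nothing measured on these compounds offers a reason for this result.

The two compounds leave open whether any chain is needed on this carbon, as they do not show it bearing only hydrogen in place of the methyl. They also leave open how a longer chain, a phenyl ring or an amine at the same place would read.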